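Halogen swap on the shared indole-type core

The source may hold more compounds than are shown below. What is called first, only, known or untested is meant among the compounds shown, and "the series" means these compounds.

Among the compounds with values here, compound 2 `Cc1noc(-c2cc3cc(F)ccc3[nH]2)n1` gives 18100 nM in a functional assay on COLO 320 cells (Homo sapiens) for antiproliferative activity, read by WST assay, with a stated time of 72 h (a lower number here means a stronger inhibitor, a higher number a weaker inhibitor), and carries the highest of the two numbers measured so far. Its nearest neighbour is compound 1 `Cc1noc(-c2cc3ccccc3[nH]2)n1` with 11800 nM; the step of a 1.5-fold higher number from compound 1 to compound 2 (0.19 log units; within the scatter) sits within the scatter, so no order between the two can be read.

Compound 3 `Cc1noc(-c2cc3cc(Cl)ccc3[nH]2)n1` differs from compound 2 by chloro in place of fluoro on an aromatic carbon. Within the data shown here, no measured step exchanges one halogen for another; the only step at this position, a 1.5-fold higher number from compound 1 to compound 2 (0.19 log units; within the scatter), shows that placing fluoro there left the number within the scatter. On that basis a step of similar size, and no clear direction, is expected for the change to chloro, giving a 1.2-fold lower number from compound 2 to compound 3 (0.08 log units; within the scatter) as the estimated step.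

Compound 3 is therefore expected to give about 15000 nM in this assay, with a range from 6000 nM to 40000 nM.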

Compound 3, half-maximal inhibitory concentration: 19500 nM
Beside the measured number, compound 3's estimate is 1.3-fold (0.11 log units) below it; the range from low to high includes it.
By their numbers in this assay, from the lowest: compounds 1, 2 and 3 (each within the scatter of the next).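

In this assay the exchange of one halogen for another on this aromatic carbon gives a 1.1-fold higher number from compound 2 to compound 3 (0.03 log units; within the scatter) and so sets no order between chloro and fluoro. Chloro in place of hydrogen gives a 1.7-fold higher number from compound 1 to compound 3 (0.22 log units; within the scatter) and likewise stays within the scatter, so hydrogen, fluoro and chloro on this carbon cannot be told apart by their numbers, and the flat picture now holds for two halogens rather than one. Nothing available explains this flat result.

Open, going by these compounds, is whether any group other than a halogen on this carbon, such as an amine, a methoxy group or a carboxylic acid, would move the number beyond the scatter. Also open, on these data alone, is whether the other carbons of that six-membered ring respond in the same way.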